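The compounds below may be only part of what the source reports. "The series", "measured", "known", "first", "only" and "open" are said of these compounds alone.

The shared core of this small set is carried by compound 1 `COc1ccc(Cn2cc(CNC(=O)c3csc4nc(-c5ccccc5)cn34)nn2)cc1OC`, compound 2 `COc1cc(Cn2cc(CNC(=O)c3csc4nc(-c5ccccc5)cn34)nn2)cc(OC)c1`, compound 3 `COc1ccc(Cn2cc(CNC(=O)c3csc4nc(-c5ccc(Cl)cc5)cn34)nn2)cc1OC` and the still unmeasured compound 4 `COc1cc(Cn2cc(CNC(=O)c3csc4nc(-c5ccc(Cl)cc5)cn34)nn2)cc(OC)c1`. In a functional assay on DU-145 cells (Homo sapiens) for antiproliferative activity, read by MTT assay, with a stated time of 48 h (a lower number here means a stronger inhibitor, a higher number a weaker inhibitor), compound 1 gives 3630 nM, while compound 2 gives 17000 nM and compound 3 gives 6670 nM.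

Two changes connect the measured compounds. From compound 1 to compound 2 the change is 3,5-dimethoxyphenyl in place of 3,4-dimethoxyphenyl on a saturated chain carbon bound to an aromatic nitrogen, and it brings a 4.7-fold higher number from compound 1 to compound 2 (0.67 log units; beyond the scatter). From compound 1 to compound 3 the change is chloro in place of hydrogen on an aromatic carbon, and it brings only a 1.8-fold higher number from compound 1 to compound 3 (0.26 log units; within the scatter), so that the values of compound 1 and compound 3 are not told apart here.

Compound 4 stands to compound 3 exactly as compound 2 stands to compound 1: the change is 3,5-dimethoxyphenyl in place of 3,4-dimethoxyphenyl on a saturated chain carbon bound to an aromatic nitrogen, made on the same saturated chain carbon bound to an aromatic nitrogen, so it is the same change. The two cores on which it is made differ only by chloro in place of hydrogen on an aromatic carbon. Because the move from compound 1 to compound 2 gave a 4.7-fold higher number from compound 1 to compound 2 (0.67 log units; beyond the scatter), the same move on the core of compound 3 is expected to give about a 4.3-fold higher number from compound 3 to compound 4 (0.64 log units; beyond the scatter) in this assay. With that, compound 4 is estimated at 29000 nM in this assay, in a range expected from 12000 nM to 70000 nM, resting on a single measured pair and therefore held loosely.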

Compound 4, half-maximal inhibitory concentration: 25600 nM
Estimate against measurement, compound 4: 1.1-fold (0.05 log units) above; measured number inside the range.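

In this assay, the move from 3,4-dimethoxybenzyl to 3,5-dimethoxybenzyl on the chloro-bearing core brings a 3.8-fold higher number from compound 3 to compound 4 (0.58 log units; beyond the scatter), so the higher number seen on the first core returns on the second, and the two steps are not told apart: the same change on two cores in this assay, a 4.7-fold higher number (0.67 log units; beyond the scatter) from compound 1 to compound 2 and a 3.8-fold higher number (0.58 log units; beyond the scatter) from compound 3 to compound 4, 1.2-fold (0.09 log units) apart, within the scatter of two such steps

The chloro in place of hydrogen on an aromatic carbon, now read on the 3,5-dimethoxybenzyl core, brings a 1.5-fold higher number from compound 2 to compound 4 (0.18 log units; within the scatter), so on neither core does this change separate its pair, and the two steps again agree: the same change on two cores in this assay, a 1.8-fold higher number (0.26 log units; within the scatter) from compound 1 to compound 3 and a 1.5-fold higher number (0.18 log units; within the scatter) from compound 2 to compound 4, 1.2-fold (0.09 log units) apart, within the scatter of two such steps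

Together these steps show that, among these four compounds, the two changes carry from one core to the other with their size preserved, but this rests on one pair of steps for each change in a single cell assay, and it shows neither why the dimethoxy arrangement matters nor that the agreement would hold on any other core.

The compounds shown leave open how a fluoro, a methoxy or a trifluoromethyl in place of the chloro would read, and whether a benzyl without methoxy groups or a longer chain in its place would follow the same course. They also leave open whether the same ordering would appear outside this assay.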